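From 4-methylphenyl to 4-hydroxyphenyl on the shared core

The compounds below may be only part of what the source reports. "The series", "measured", "known", "first", "only" and "open" are said of these compounds alone.

In a functional assay on HCT-116 cells (Homo sapiens) for inhibition, read by WST assay, with stated times of 72 h and 2 h (on this read-out lower numbers stand for stronger inhibition and higher numbers for weaker inhibition), compound 1 `OC(c1cccs1)c1cc2ccccc2nc1Cl` gives 69300 nM as its value. Compound 2 `C#CCOC(c1cccs1)c1cc2ccccc2nc1Cl` reports only a limit, > 100000 nM in this read-out. Compound 3 `Cc1ccc(-c2cc(COC(c3cccs3)c3cc4ccccc4nc3Cl)on2)cc1` gives 115000 nM and stands within the scatter of compound 1. Compound 4 `Oc1ccc(-c2cc(COC(c3cccs3)c3cc4ccccc4nc3Cl)on2)cc1` differs from compound 3 as follows: hydroxy in place of methyl on an aromatic carbon with hydroxy in place of methyl on an aromatic carbon. For the measured compounds named here, the only measured step of an at least 1.4-fold higher number from compound 1 to compound 2 (0.15 log units; that floor lies within the scatter) rests on the limit of > 100000 nM in this assay, at which 1 of the 3 values shown sits, and lies at another place, propargyl in place of hydrogen on an oxygen on a saturated carbon. Going by the values given here, no measured step touches the new place, so the expectation rests on compound 3 at 115000 nM and no step beyond the scatter is expected in this assay for this change. The estimated step of a 1.4-fold lower number from compound 3 to compound 4 (0.16 log units; within the scatter) stays within the scatter. Compound 4 is expected at 80000 nM with an estimated range from 30000 nM to 170000 nM in this read-out.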

Compound 4, half-maximal inhibitory concentration: "not active" (no number reported)
For compound 4 the study gives words and no number, so the estimate cannot be set against anything.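

In this assay, for the compounds shown here, compound 4 is reported as not active, without a number, so no step from compound 3 to compound 4 can be read. Left open is whether 4-hydroxyphenyl differs from 4-methylphenyl on the shared core, and compound 2 also stands only as a limit: the limit of > 100000 nM in this assay, at which 1 of the 4 values shown sits.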